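Capping a Free Hydroxy Group with an Acetyl

The compounds below may be only part of what the source reports. "The series", "measured", "known", "first", "only" and "open" are said of these compounds alone.

Compound 1 `C=C1C(=O)O[C@]2(C)CC[C@@H]1C[C@H](O)[C@@]1(C)CC[C@H](O1)[C@](C)(O)CC[C@H]2OC(C)=O` and compound 2 `C=C1C(=O)O[C@]2(C)CC[C@@H]1C[C@H](O)[C@@]1(C)CC[C@H](O1)C(=C)CC[C@H]2OC(C)=O` share one core. In a functional assay on Doay cells (Homo sapiens) for cytotoxicity (a lower number here means a stronger inhibitor, a higher number a weaker inhibitor), compound 1 gives > 20 ug/mL, a limit of the assay rather than a number. In this assay compound 2 likewise gives > 20 ug/mL, again only a limit. Both values sit at the limit of > 20 ug/mL in this assay, at which 2 of the 2 values shown sit, so neither compound shows measurable cytotoxicity here. Compound 3 `C=C1C(=O)O[C@]2(C)CC[C@@H]1C[C@H](OC(C)=O)[C@@]1(C)CC[C@H](O1)C(=C)CC[C@H]2OC(C)=O` differs from compound 2 by acetyl in place of hydrogen on an oxygen on a saturated carbon. Among the measured compounds shown here, no measured step guides this change, so for compound 3 the expected step is a step that the limit leaves unreadable from compound 2 to compound 3, within the usual scatter. Compound 3 is expected to give 25 ug/mL, within 12 ug/mL to 60 ug/mL, most likely reported again as a limit.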

Compound 3, half-maximal inhibitory concentration: > 20 ug/mL
Compound 3 ended at the assay's limit; the forecaster's own chance of this, stated with the estimate: 80%; the middle value lies beyond the limit too.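

Compound 2 and compound 3 both stop at a limit, so the change from hydroxy to acetoxy gives no readable step: the limit of > 20 ug/mL in this assay, at which 3 of the 3 values shown sit.

The compounds shown leave open whether this change alters cytotoxicity at all in this assay.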